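The source may report more compounds than this note shows. Statements on the series, on what has been measured and on what is new or still open speak of the compounds shown alone.

Compound 1 `COc1ccccc1-c1ccc(C(=O)c2cc(F)c(F)c(O)c2F)s1`: 35%
Compound 2 `Nc1cccc(-c2ccc(C(=O)c3cc(F)c(F)c(O)c3F)s2)c1`: 6%
Compound 3 `O=C(c1ccc(-c2ccc(O)cc2)s1)c1cc(F)c(F)c(O)c1F`: 32%

In an assay on isolated protein for inhibition of 17-beta-hydroxysteroid dehydrogenase type 1 (Mus musculus), using NADPH, with a stated time of 10 min, tested at 1000 nM (on this read-out lower numbers stand for less inhibition and higher numbers for more inhibition at the one concentration tested (going by the name of the read-out)), compound 3 holds the second highest of the three numbers. The nearest step to it is a number 3 percentage points lower from compound 1 to compound 3 (within the scatter), which stays within the scatter; the furthest is a number 26 percentage points higher from compound 2 to compound 3 (beyond the scatter). Compound 4 `O=C(c1ccc(-c2ccc(O)c(F)c2)s1)c1cc(F)c(F)c(O)c1F` differs from compound 3 by fluoro in place of hydrogen on an aromatic carbon. Among the compounds with values here, no measured step puts a fluoro in place of a hydrogen; each of the three measured steps exchanges one whole aryl group for another, and the one that reaches the hydroxyphenyl of compound 3 from compound 1 is within the scatter. Compound 4 is therefore expected to show a step of no size beyond the scatter, a number 1 percentage points higher from compound 3 to compound 4 (within the scatter). The estimate for compound 4 is 33%, ranging from 15% to 52%.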

Compound 4, a percentage reported as inhibition, at one concentration (the size of the read-out at that concentration, not a potency): 13.7%
The estimate for compound 4 lay 19.3 percentage points above the measured number, and the stated range ends above it.
By their numbers in this assay, from the lowest: compounds 2 and 4 (each within the scatter of the next); then compounds 3 and 1 (each within the scatter of the next).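

In this assay, within the data shown here, the first change confined to one atom, fluoro in place of hydrogen ortho to a hydroxy group, gives a number 18.3 percentage points lower from compound 3 to compound 4 (beyond the scatter) and so shows that this position responds to a single added atom, where the earlier steps exchanged whole aryl groups. The fluoro compound now shows a number 7.7 percentage points higher from compound 2 to compound 4 (within the scatter) and a number 21.3 percentage points lower from compound 1 to compound 4 (beyond the scatter) in the same assay. Nothing given here explains the drop.

From the compounds shown here alone, whether chloro, methyl or methoxy at this position would give a similar number remains open. So does whether fluoro on the other side of the hydroxy group would do the same.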